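The source may report more compounds than this note shows. Statements on the series, on what has been measured and on what is new or still open speak of the compounds shown alone.

Of the compounds shown here, two from this series have been measured for how well they dissolve in water. Compound 1 `COc1ccc2c(c1)NC(=O)CN2c1nc(NCCCO)nc2ccccc12` gives 80.9 ug/mL in a physicochemical assay for solubility, read by HPLC, at pH 7.4; on this read-out higher numbers stand for higher solubility and lower numbers for lower solubility. Compound 2 `COc1ccc2c(c1)NC(=O)CN2c1nc(NC2CC2)nc2ccccc12` gives 67.8 ug/mL in this assay. For the measured compounds named here, the only single change measured so far is a 1.2-fold lower number from compound 1 to compound 2 (0.08 log units; within the scatter), so compound 2 stands at the lower of the two numbers, but the gap to compound 1 is one that repeated measurements could produce on their own.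

Compound 3 `CCCCNc1nc(N2CC(=O)Nc3cc(OC)ccc32)c2ccccc2n1` is not yet measured. It differs from compound 2 in one place: butyl in place of cyclopropyl on a nitrogen on an aromatic ring. Going by the values given here, no measured step swaps one carbon chain for another of this kind; the one step available, from compound 1 to compound 2, exchanged a hydroxypropyl for a cyclopropyl and stayed within the scatter, so it offers only indirect guidance. With one more carbon and no ring, a small drop seems the most reasonable expectation, and the step from compound 2 to compound 3 is estimated as a 1.7-fold lower number from compound 2 to compound 3 (0.23 log units; within the scatter). Compound 3 is therefore expected to give about 40 ug/mL in this assay, most likely between 18 ug/mL and 90 ug/mL.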

Compound 3, solubility: 1.34 ug/mL
For compound 3 the middle estimate is 30-fold (1.47 log units) above the measured one; the whole stated range lies above it.
By their numbers in this assay, from the lowest: compound 3; then compounds 2 and 1 (each within the scatter of the next).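

The group on this nitrogen matters far more in this assay than the first two compounds suggested: a 51-fold lower number from compound 2 to compound 3 (1.70 log units; beyond the scatter), although the change only replaces a three-carbon ring with an open four-carbon chain and neither group has a hydrogen-bond donor or acceptor. The other step tells a similar story, with a 60-fold lower number from compound 1 to compound 3 (1.78 log units; beyond the scatter), for methyl in place of hydroxy on the saturated chain carbon, while compounds 1 and 2 remain within the scatter of each other despite their different groups. So, among these three compounds, only the butyl compound stands apart, and nothing measured here accounts for the size of this fall.

The compounds shown leave open whether the low number goes with the open chain or with the fourth carbon, a question that cyclobutyl in place of butyl or a shorter chain such as ethyl could help to separate. They also leave open whether an amine at the end of the butyl chain would give a number closer to those of compound 1 and compound 2.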